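A New Group on Sulfur in a Level Series

A few compounds are considered here, and "the series" means these few. Any claim that something is new, unique, unknown or untested is made for them only; others in the source may bear on it.

Three related compounds have been measured in a functional assay on DU-145 cells (Homo sapiens) for inhibition, read by trypan blue exclusion, with a stated time of 96 h; on this read-out higher numbers stand for weaker inhibition of growth and lower numbers for stronger inhibition of growth. Compound 1 (`O=C(/C(=C\c1ccc(O)c([N+](=O)[O-])c1)SCc1ccc(Br)cc1)c1ccc(Br)cc1`) gives 10000 nM, compound 2 (`O=C(/C(=C\c1ccc([N+](=O)[O-])c(O)c1)SCc1ccc(Br)cc1)c1ccc(Br)cc1`) gives 10000 nM and compound 3 (`O=C(/C(=C\c1ccc([N+](=O)[O-])c(O)c1)SCc1ccc(Br)cc1)c1c(F)c(F)c(F)c(F)c1F`) gives 10000 nM, so compound 2 stands level with both of the others. The next candidate is compound 4 (`O=C(/C(=C\c1ccc([N+](=O)[O-])c(O)c1)Sc1c(F)c(F)c(F)c(F)c1F)c1ccc(Br)cc1`), which differs from compound 2 at a single place: 2,3,4,5,6-pentafluorophenyl in place of 4-bromobenzyl on a sulfur. In words, 2,3,4,5,6-pentafluorophenyl replaces 4-bromobenzyl on a sulfur.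

Two measured steps offer guidance. The closer one brings the same 2,3,4,5,6-pentafluorophenyl into the molecule, although on a carbonyl carbon and in place of 4-bromophenyl, and it gave no change at the digits printed from compound 2 to compound 3 (within the scatter). The other exchanged 4-hydroxy-3-nitrophenyl for 3-hydroxy-4-nitrophenyl and gave no change at the digits printed from compound 1 to compound 2 (within the scatter). Among the compounds with values here, neither step touches the group on sulfur, so the data hold no direct precedent for this change, and a surprise remains possible. With no measured step beyond the scatter to build on, no shift beyond the scatter is expected, and the estimated step is a 1.3-fold lower number from compound 2 to compound 4 (0.10 log units; within the scatter). The expected value for compound 4 is 8000 nM, with an estimated range from 2500 nM to 12000 nM.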

Compound 4, concentration for 50% growth inhibition: 10000 nM
For compound 4 the middle estimate is 1.3-fold (0.10 log units) below the measured one; measured number inside the range.
By their numbers in this assay, from the lowest: compounds 1, 2, 3 and 4 (each within the scatter of the next).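

In this assay the exchange of 4-bromobenzyl for 2,3,4,5,6-pentafluorophenyl on a sulfur gave no change at the digits printed from compound 2 to compound 4 (within the scatter) and so this position, which neither earlier step touched, now has a measured change of its own. The exchange is a real change of group, from one made of carbon and bromine to one made of carbon and fluorine, although both groups hold one six-membered aromatic ring of carbon only. Taken with the two earlier steps, this makes three single-place changes around compound 2, and none of them moves the number beyond the scatter. No measurement in hand bears on why the number held.

On these data alone, it remains open whether a group on the sulfur without an aromatic ring, such as a short alkyl chain or a chain ending in an amine or a carboxylic acid, would shift the number. As far as these compounds go, it is also open whether 2,3,4,5,6-pentafluorophenyl on both the sulfur and the carbonyl carbon in one molecule would behave as each single exchange does.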